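This account rests on a few compounds, and the source may have more. Where it says the series, first, only, none or still open, it means among the compounds named here.

In a functional assay on DU-145 cells (Homo sapiens) for inhibition, read by trypan blue exclusion, with a stated time of 96 h (on this read-out higher numbers stand for weaker inhibition of growth and lower numbers for stronger inhibition of growth), compound 1 `CCOc1ccc(/C=C(\C(=O)c2ccc(Cl)cc2)S(=O)(=O)Cc2ccc(F)cc2)cc1OC` gives 50000 nM and compound 2 `CCOc1ccc(/C=C(\C(=O)c2ccc(Cl)cc2)S(=O)(=O)Cc2ccc(C)cc2)cc1OC` gives 10000 nM, the lower of these two numbers. Compound 3 `CCOc1ccc(/C=C(/SCc2ccc(C)cc2)C(=O)c2ccc(Cl)cc2)cc1OC` has (4-methylbenzyl)sulfanyl in place of the (4-methylbenzyl)sulfonyl of compound 2 on a double-bonded chain carbon bound to a carbonyl carbon and a double-bonded chain carbon: (4-methylbenzyl)sulfanyl in place of (4-methylbenzyl)sulfonyl on a double-bonded chain carbon bound to a carbonyl carbon and a double-bonded chain carbon. Within the data shown here, the only measured step, a 5.0-fold lower number from compound 1 to compound 2 (0.70 log units; beyond the scatter), put methyl in place of fluoro elsewhere, so it shows a modest scale but no direction for this change. No step beyond the scatter is therefore expected in this assay, though one of that modest size either way remains possible. The estimated step is a 1.3-fold lower number from compound 2 to compound 3 (0.10 log units; within the scatter). For compound 3 the estimated value is 8000 nM, with an expected range of 1500 nM to 40000 nM.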

Compound 3, concentration for 50% growth inhibition: 25000 nM
Compound 3: the middle estimate sits 3.1-fold (0.49 log units) below what was measured, within the range that was stated.
By their numbers in this assay, from the lowest: compound 2; then compounds 3 and 1 (each within the scatter of the next).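

At this double-bonded chain carbon, (4-methylbenzyl)sulfanyl in place of (4-methylbenzyl)sulfonyl gives a 2.5-fold higher number from compound 2 to compound 3 (0.40 log units; beyond the scatter) in this assay, so this position does respond to the change, and the direction is towards weaker inhibition of growth. The step of a 2.0-fold lower number from compound 1 to compound 3 (0.30 log units; within the scatter) stays within the scatter, so those two compounds cannot be told apart. Nothing available here explains either step.

Open, going by these compounds, is how a sulfinyl group or an amine would read at this carbon. Also open, on these data alone, is whether swapping methyl for fluoro on the benzyl ring has the same effect in a (4-fluorobenzyl)sulfanyl pair.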